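A few compounds are considered here, and "the series" means these few. Any claim that something is new, unique, unknown or untested is made for them only; others in the source may bear on it.

Measured so far in a functional assay on Caco-2 cells (Homo sapiens) for activation, read by fluorescence, tested at 1 uM; a higher number here means a weaker effect of the compound at the concentration tested, a lower number a stronger effect:

compound 1, `COc1cc(/C=C/C2=CC(=O)CC(c3ccc(O)c(OC)c3)N2CCCO)ccc1O`, 95.6%
compound 2, `COCCCN1C(/C=C/c2ccc(O)cc2)=CC(=O)CC1c1ccc(O)cc1`, 99%
compound 3, `O=C(/C=C(/C=C/c1ccc(O)cc1)NCCCO)/C=C/c1ccc(O)cc1`, 94.1%

All three compounds share a backbone of two hydroxyphenyl-bearing arms around a central ketone, and all three give numbers close to the top of the scale in this assay, meaning each has only a weak effect at the single concentration tested. Compound 3 has the lowest of the three numbers, but the gap to compound 1 and the gap to compound 2 both lie within the usual scatter, so nothing separates the three on this evidence.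

Compound 4, `COCCCNC(=C\C(=O)/C=C/c1ccc(O)cc1)/C=C/c1ccc(O)cc1`, is the next compound and has not yet been measured. It differs from compound 3 in one place: methyl in place of hydrogen on an oxygen on a saturated carbon. The same kind of group, a methoxy on a chain carbon, is present in compound 2, which gives 99%, a number no different from the others within the scatter.

For the measured compounds named here, with every number so far sitting in the same narrow band, the step from compound 3 to compound 4 is expected to be small, a number 1.9 percentage points higher from compound 3 to compound 4 (within the scatter), not beyond the scatter in either direction. Compound 4 is therefore expected to give about 96% in this assay, likely between 88% and 103%.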

Compound 4, a percentage reported as activity, at one concentration (the size of the read-out at that concentration, not a potency): 97%
Compound 4: middle estimate off by 1 percentage points, on the low side, and the stated range covers the measured number.
By their numbers in this assay, from the lowest: compounds 3, 1, 4 and 2 (each within the scatter of the next).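

Methyl in place of hydrogen on an oxygen on a saturated carbon, the change of hydroxy to methoxy, gives a number 2.9 percentage points higher from compound 3 to compound 4 (within the scatter) in this assay. This is the first pair shown that differs in only one place, so it reads the change directly: at the single concentration tested, capping this hydroxy with a methyl leaves the read-out within the scatter, with both compounds still showing only a weak effect. No measured evidence here explains this result.

Going by these compounds, it remains open whether a different group at the end of this chain, such as an amine, a carboxylic acid or a longer chain, would move the number beyond the scatter. The pair also cannot show whether hydroxy to methoxy would behave the same way on the core of compound 2.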